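This account rests on a few compounds, and the source may have more. Where it says the series, first, only, none or still open, it means among the compounds named here.

Measured in a functional assay on PC-3 cells (Homo sapiens) for inhibition, read by MTT assay, with a stated time of 48 h; on this read-out higher numbers stand for weaker inhibition and lower numbers for stronger inhibition:
- compound 1 `COc1ccc(-n2c(S)nnc2-c2cc(OC)c(OC)c(OC)c2)cc1`: > 60000 nM (a limit)
- compound 2 `CCOC(=O)CSc1nnc(-c2cc(OC)c(OC)c(OC)c2)n1-c1ccc(OC)cc1`: > 60000 nM (a limit)

Neither compound has a true number yet, and the whole picture so far is the limit of > 60000 nM in this assay, at which 2 of the 2 values shown sit. On these data alone, compound 2 therefore stands at a limit, > 60000 nM, and how far its real value lies beyond that is unknown.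

Compound 3 `COc1ccc(-n2c(SCC(=O)Nc3ccc(Cl)cc3)nnc2-c2cc(OC)c(OC)c(OC)c2)cc1` keeps the shared core and the sulfur-linked chain of compound 2 but changes the end of that chain: (4-chlorophenyl)amino in place of ethoxy on a carbonyl carbon. In words, ethoxycarbonyl becomes (4-chlorophenyl)carbamoyl.

Going by the values given here, the one measured step that bears on this is a step that the two limits leave unreadable from compound 1 to compound 2, which concerns the same group on the sulfur. It gives no size to build on, so the expectation rests on a weak basis. Only a move towards stronger inhibition could show up as a number in this assay, and another limit reading remains quite possible.

The expected step, a rough estimate only, is an at least 2.4-fold lower number from compound 2 to compound 3 (0.38 log units; beyond the scatter). For compound 3 the estimated value is 25000 nM, with an expected range from 4000 nM to 90000 nM.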

Compound 3, half-maximal inhibitory concentration: 6290 nM
Compound 3: middle estimate off by 4.0-fold (0.60 log units), on the high side, and the stated range covers the measured number.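

Within this assay the end of the sulfur-linked chain turns out to matter: (4-chlorophenyl)amino in place of ethoxy on a carbonyl carbon gives an at least 9.5-fold lower number from compound 2 to compound 3 (0.97 log units; beyond the scatter) and so yields the first true number in this small set. Compared with hydrogen on the sulfur, ((4-chlorophenyl)carbamoyl)methyl gives an at least 9.5-fold lower number from compound 1 to compound 3 (0.97 log units; beyond the scatter) while the step from hydrogen to (ethoxycarbonyl)methyl cannot be read, so a chain on the sulfur does not by itself bring a measurable value, since compound 2 also carries one and stays at a limit. The true sizes of both readable steps may be larger, because only compound 3 has a real number and the other two values are limits: the limit of > 60000 nM in this assay, at which 2 of the 3 values shown sit.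

The change brings in an amide hydrogen, an aromatic ring and a chlorine all at once, and the compounds shown cannot tell which of these matters. On these data alone, whether a plain phenylamino group, a benzylamino group, a simple amine or a carboxylic acid at the same carbonyl carbon would give a similar number remains open.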